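The compounds below may be only part of what the source reports. "The series", "measured", "known", "first", "only" and "open" are said of these compounds alone.

Measured so far:
- compound 1, `CCN1CCN(c2ccc3c(c2)oc(=O)n3C(=O)NCCCCc2ccccc2)CC1`: 56 nM
- compound 2, `CN1CCC(c2ccc3c(c2)oc(=O)n3C(=O)NCCCCc2ccc(F)cc2)CC1`: 94 nM

Both were tested in an assay on HEK293 cells for inhibition of acid ceramidase (Homo sapiens), read by fluorescence, with stated times of 10 min and 3 h; a higher number here means a weaker inhibitor, a lower number a stronger inhibitor. Compound 1 gives 56 nM and compound 2 gives 94 nM; the gap between them is within the usual scatter of repeated measurements, so on these numbers the two stand level, and neither can be called the stronger inhibitor.

The next compound, compound 3, `CC(=O)N1CCC(c2ccc3c(c2)oc(=O)n3C(=O)NCCCCc2ccccc2)CC1`, shares the core of compound 1 and differs in one place: 1-acetylpiperidin-4-yl in place of 4-ethylpiperazin-1-yl on an aromatic carbon. For the measured compounds named here, no measured pair shows this particular change, so nothing in the data says how large a step it makes.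

Only a cautious guess is possible. The expected step from compound 1 to compound 3 in this assay is a 2.1-fold higher number from compound 1 to compound 3 (0.33 log units; beyond the scatter), toward a somewhat weaker inhibitor, though small enough that it could still fall inside the scatter. For compound 3 the estimate in this assay is 120 nM, with a range from 40 nM to 400 nM.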

Compound 3, half-maximal inhibitory concentration: 64 nM
The estimate for compound 3 lay 1.9-fold (0.27 log units) above the measured number, within the range that was stated.
By their numbers in this assay, from the lowest: compounds 1, 3 and 2 (each within the scatter of the next).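

In this assay, the result is a 1.1-fold higher number from compound 1 to compound 3 (0.06 log units; within the scatter), so this aromatic carbon accepts 1-acetylpiperidin-4-yl in place of 4-ethylpiperazin-1-yl with no change that can be told from scatter. For the compounds shown here, this is the first direct reading of a single change at this position, and it shows that two quite different six-membered rings, one of which brings a double bond outside aromatic rings, can give matching numbers. No measurement at hand bears on why the two groups stand level.

This one swap cannot show how much freedom the position allows overall, since both groups are six-membered non-aromatic rings holding nitrogen. A carboxylic acid or a small primary amine on the same carbon would test the position with a very different kind of group.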